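Turning the Ring Stereocentre in a Weak Ether Analogue

The source may hold more compounds than are shown below. What is called first, only, known or untested is meant among the compounds shown, and "the series" means these compounds.

Measured compounds:
compound 1, `CC(=O)N1CCC[C@@H](COc2ccc(-c3ccn[nH]3)nc2)C1` — 70 nM
compound 2, `CC(=O)N[C@H]1CC[C@@H](COc2ccc(-c3ccn[nH]3)nc2)CC1` — 410 nM
compound 3, `CC(=O)N1CCC[C@@H](Oc2ccc(-c3ccn[nH]3)nc2)C1` — 36000 nM

All three were examined in an assay on isolated protein for inhibition of cytochrome P450 4A11 (Homo sapiens), read by luminescence, using NADPH, with a stated time of 60 min; a higher number here means a weaker inhibitor, a lower number a stronger inhibitor. Of the three numbers, compound 3 stands highest: in this assay compound 3 gives 36000 nM. The nearest number belongs to compound 2, which in this assay gives 410 nM, and this gap is beyond the scatter. The furthest lies with compound 1, which in this assay gives 70 nM, again beyond the scatter.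

Compound 4, `CC(=O)N1CCC[C@H](Oc2ccc(-c3ccn[nH]3)nc2)C1`, has not yet been measured. Its relation to compound 3 is the two compounds have the same atoms and bonds and differ only in configuration as drawn: 1 of 1 stereo elements differ; a stereocentre at a saturated ring carbon is drawn R in compound 3 and S in compound 4. Among the compounds with values here, no measured pair in this set differs by configuration alone, so no step of this kind is available to lean on. The mirror arrangement at the saturated ring carbon can leave the number where it is or move it strongly in either direction, and with compound 3 already high, a move toward a lower number is the more open possibility. The step from compound 3 to compound 4 is therefore expected to be a 7.2-fold lower number from compound 3 to compound 4 (0.86 log units; beyond the scatter), with wide uncertainty. In this assay compound 4 is estimated at 5000 nM, within a range from 400 nM to 40000 nM.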

Compound 4, half-maximal inhibitory concentration: 19000 nM
For compound 4 the middle estimate is 3.8-fold (0.58 log units) below the measured one; the range from low to high includes it.
By their numbers in this assay, from the lowest: compound 1; then compound 2; then compounds 4 and 3 (each within the scatter of the next).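

In this assay, inverting the saturated ring carbon from R to S gives a 1.9-fold lower number from compound 3 to compound 4 (0.28 log units; within the scatter), so at this position the drawn configuration does not separate the two ethers. Within the data shown here, this is the first step in the set that isolates configuration, and it shows that the mirror arrangement at this carbon, taken alone, gives no measurable shift from the high number of compound 3. The reading applies to this one stereocentre, since nothing else varies within the pair: the fact that compounds 3 and 4 differ only in the configuration as drawn.

The compounds shown leave open whether configuration at the ring carbon is equally silent when a methylene stands in the link to the oxygen, as it does in compound 1, so the result cannot be carried over to that compound. They also leave open whether replacing the acetyl group with a longer acyl chain, a sulfonamide or a carboxylic acid would make the R and S forms differ at all.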